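A few compounds are considered here, and "the series" means these few. Any claim that something is new, unique, unknown or untested is made for them only; others in the source may bear on it.

Working notes on the urea series. Compound 1 `Cn1ncc2c(NC(=O)NCc3cc(C(C)(C)C)nn3-c3cccc(Cl)c3)cccc21` carries the methylated indazole together with a chlorophenyl group; in an assay on CHO-K1 cells for antagonist activity at transient receptor potential cation channel subfamily V member 1 (Homo sapiens), read by FLIPR and calcium flux, with a stated time of 6 min (a higher number here means a weaker inhibitor, a lower number a stronger inhibitor), compound 1 gives 0.4 nM. Compound 2 `CC(C)(C)c1cc(CNC(=O)Nc2cccc3[nH]ncc23)n(-c2cccc(C(F)(F)F)c2)n1` carries the unmethylated indazole together with a trifluoromethylphenyl group; in this assay compound 2 gives 0.3 nM. Among the compounds with values here, the two numbers lie within the usual scatter of each other, so no order between compound 1 and compound 2 can be read from them, and the pair differs in two places at once, so no single step is defined.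

Compound 3 `Cn1ncc2c(NC(=O)NCc3cc(C(C)(C)C)nn3-c3cccc(C(F)(F)F)c3)cccc21` is not yet measured. Relative to compound 2 the change is methyl in place of hydrogen on an aromatic nitrogen, read one bond further out as 1H-indazol-4-yl to 1-methyl-1H-indazol-4-yl. Within the data shown here, no measured pair isolates this change. Compound 1 already carries the methyl on that nitrogen and gives 0.4 nM, so nothing points to a step beyond the scatter. The expected step from compound 2 to compound 3 is a 1.3-fold higher number from compound 2 to compound 3 (0.12 log units; within the scatter), essentially none. Compound 3 is accordingly estimated at 0.4 nM, with a range of 0.15 nM to 1 nM.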

Compound 3, inhibition constant: 0.6 nM
Beside the measured number, compound 3's estimate is 1.5-fold (0.18 log units) below it, and the stated range covers the measured number.
By their numbers in this assay, from the lowest: compounds 2, 1 and 3 (each within the scatter of the next).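

Within the data shown here, compound 3 gives the first pair that isolates methyl in place of hydrogen on an aromatic nitrogen: in this assay the step reads a 2.0-fold higher number from compound 2 to compound 3 (0.30 log units; within the scatter) and places no measurable difference between the 1H-indazol-4-yl and 1-methyl-1H-indazol-4-yl groups in this pair. Among these compounds, it also gives the first single-place reading of trifluoromethyl in place of chloro on an aromatic carbon: the step of a 1.5-fold higher number from compound 1 to compound 3 (0.18 log units; within the scatter) does not separate the two groups when the 1-methyl-1H-indazol-4-yl group is present. No measurement is available that bears on either step, so the numbers stand without explanation.

As far as these compounds go, all three compounds lie within the scatter of their neighbours in the order, so it remains open whether either place can move the number at all. Also open, from the compounds shown here alone, are the reading for an ethyl group or a longer chain on that aromatic nitrogen, and for a nitrile or a methoxy group on the aromatic carbon that carries chloro or trifluoromethyl.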